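Side-chain exchange on a benzyl ester amide series

The source may hold more compounds than are shown below. What is called first, only, known or untested is meant among the compounds shown, and "the series" means these compounds.

Three compounds of the series have numbers in a functional assay on the whole organism (Tail, strain ICR) with Mus musculus as the target, in the tail flick test, with a stated time of 60 min, at a dose of 25 umol/kg by the oral route; a lower number here means a weaker effect, a higher number a stronger effect of the compound at the dose given. Compound 1 `O=C(O)[C@@H]1CCCN1C(=O)CN(c1nc(Cl)nc2[nH]cnc12)C1CC1` gives 34.9% in this assay. Compound 2 `NCCCC[C@H](NC(=O)CN(c1nc(Cl)nc2[nH]cnc12)C1CC1)C(=O)OCc1ccccc1` gives 41.2% in this assay. Compound 3 `CC(C)[C@H](NC(=O)CN(c1ncnc2c1ncn2C1CCCCO1)C1CC1)C(=O)OCc1ccccc1`, which carries a different core, gives 34.9% in this assay. Compound 2 holds the highest of the three numbers, but its distance to compound 1 and to compound 3 lies within the scatter, so the three compounds cannot be told apart on these numbers.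

Compound 4 `O=C(CN(c1nc(Cl)nc2[nH]cnc12)C1CC1)N[C@@H](CCC(=O)OCc1ccccc1)C(=O)OCc1ccccc1` has not been measured in this assay. It keeps the core and the cyclopropyl amine of compound 2 and differs in the side chain of the amino acid part: benzyloxycarbonyl in place of 2-aminoethyl on a saturated chain carbon, three bonds along the chain from an amide-type nitrogen and a carbonyl carbon.

For the measured compounds named here, no step between two measured compounds is available for this change, and no measured pair shows a difference beyond the scatter. Going by the values given here, the expectation for compound 4 therefore rests on the narrow spread of the three known numbers alone. The step of a number 4.2 percentage points lower from compound 2 to compound 4 (within the scatter) is expected to be small, in no clear direction, and not beyond the scatter. Compound 4 is estimated at 37% in this assay, with a range from 22% to 54%.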

Compound 4, a percentage reported as activity, at one dose (the size of the read-out at that dose, not a potency): 53.7%
Compound 4: middle estimate off by 16.7 percentage points, on the low side; the range from low to high includes it.
By their numbers in this assay, from the lowest: compounds 1, 3 and 2 (each within the scatter of the next); then compound 4.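

The side chain of the amino acid part is a place where this assay responds: benzyloxycarbonyl in place of 2-aminoethyl on a saturated chain carbon, three bonds along the chain from an amide-type nitrogen and a carbonyl carbon, gives a number 12.5 percentage points higher from compound 2 to compound 4 (beyond the scatter). For the compounds shown here, this is the first step that is tied to one place and lies beyond the scatter, and it shows that the amine at the chain end of compound 2 is not needed for the effect seen at this dose. Nothing on hand accounts for the size or direction of this step.

The change removes the amine and brings in the ester and its aromatic ring in one move, so the compounds shown cannot assign the step to the loss of the one or the gain of the other. A free carboxylic acid at the end of this side chain, or a longer chain carrying the same benzyl ester, would help separate these parts, and the single dose leaves potency open.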